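A few compounds are considered here, and "the series" means these few. Any claim that something is new, unique, unknown or untested is made for them only; others in the source may bear on it.

Three compounds have been measured in a functional assay on HeLa cells (Homo sapiens) for antiproliferative activity, read by CCK-8 assay, with a stated time of 72 h, tested at 2 uM; a lower number here means a weaker effect, a higher number a stronger effect of the compound at the concentration tested:

compound 1, `Nc1ccccc1NC(=O)c1ccc(CSC(=S)N2CCN(c3ccc(Cl)cc3)CC2)cc1`, giving 51.2%
compound 2, `Nc1ccccc1NC(=O)c1ccc(CSC(=S)N2CCc3ccc([N+](=O)[O-])cc32)cc1`, giving 45.7%
compound 3, `Nc1ccccc1NC(=O)c1ccc(CSC(=S)N2CCN(C(c3ccccc3)c3ccccc3)CC2)cc1`, giving 8%

Compound 1 shows the highest of the three numbers. The gap between compound 1 and compound 2 lies within the usual scatter of repeated measurements, so the two cannot be separated on these data, and neither may be called the more active of the pair. Compound 3, by contrast, stands far below compound 1, by a margin well beyond the scatter.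

Compound 4, `Nc1ccccc1NC(=O)c1ccc(CSC(=S)N2CCN(c3ccc(F)cc3)CC2)cc1`, has not yet been measured. It differs from compound 1 in one place: fluoro in place of chloro on an aromatic carbon. Within the data shown here, no measured pair in this set shows the effect of such a change, so no step can be read off directly.

A change of this kind, a single halogen exchanged for another on the same aromatic carbon, is expected to move the read-out little. Compound 4 is estimated to give about 46%, within a range from 32% to 60%. That estimate means an expected step of a number 5.2 percentage points lower from compound 1 to compound 4 (within the scatter), which is expected to stay within the scatter, with no direction that can be asserted beyond it.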

Compound 4, a percentage reported as inhibition, at one concentration (the size of the read-out at that concentration, not a potency): 60.8%
For compound 4 the middle estimate is 14.8 percentage points below the measured one; the whole stated range lies below it.
By their numbers in this assay, from the lowest: compound 3; then compounds 2, 1 and 4 (each within the scatter of the next, the first and the last beyond it).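

In this assay the first step read at this position, fluoro in place of chloro on an aromatic carbon para to a large group, is a number 9.6 percentage points higher from compound 1 to compound 4 (within the scatter). The two halogens therefore cannot be separated at this carbon on these data, and neither compound 1 nor compound 4 may be called the more active of the pair. Nothing shown gives a reason for this result or bears on it.

The compounds shown leave open whether a bromo, methyl, methoxy or amino group on the same carbon would also stay within the scatter of these two halogens, or would move the read-out beyond it. Going by these compounds, it also remains open whether a carboxylic acid there, or a hydrogen in place of the halogen, would keep a read-out comparable to that of compound 4.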